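Expecting the Effect of a Methoxy Group

The compounds below may be only part of what the source reports. "The series", "measured", "known", "first", "only" and "open" are said of these compounds alone.

Measured so far:
compound 1 `C=C(Br)C(=O)Nc1cccc(-c2cn3nc(Cc4ccccc4)sc3n2)c1` — 3000 nM
compound 2 `Nc1cccc(-c2cn3nc(Cc4ccccc4)sc3n2)c1` — 7400 nM

In a functional assay on L1210 cells (Mus musculus) for inhibition, read by cell counting, with a stated time of 2 days (a lower number here means a stronger inhibitor, a higher number a weaker inhibitor), compound 1 gives 3000 nM, while compound 2 gives 7400 nM. Among the measured compounds shown here, compound 2 therefore stands highest of the two numbers, and the only measured step is a 2.5-fold higher number from compound 1 to compound 2 (0.39 log units; beyond the scatter).

Compound 3 `COc1cccc(Cc2nn3cc(-c4cccc(N)c4)nc3s2)c1` differs from compound 2 in one place: methoxy in place of hydrogen on an aromatic carbon. For the measured compounds named here, no measured step touches this place. Going by the values given here, the single step of a 2.5-fold higher number from compound 1 to compound 2 (0.39 log units; beyond the scatter) concerns a nitrogen on an aromatic ring, a different part of the shared core, and shows only that a modest change there moved the number modestly. Nothing measured says what a methoxy group on the other ring does, so the expectation is a step of no size beyond the usual scatter, in no particular direction.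

Compound 3 is expected to give about 7000 nM, within a range from 2500 nM to 20000 nM. The expected step from compound 2 is a 1.1-fold lower number from compound 2 to compound 3 (0.02 log units; within the scatter).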

Compound 3, half-maximal inhibitory concentration: 21000 nM
The estimate for compound 3 lay 3.0-fold (0.48 log units) below the measured number; measured number outside the range, above it.
By their numbers in this assay, from the lowest: compound 1; then compound 2; then compound 3.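

In this assay, replacing phenyl with 3-methoxyphenyl gives a 2.8-fold higher number from compound 2 to compound 3 (0.45 log units; beyond the scatter), the first measured sign that this part of the molecule is not indifferent to what it carries. The step is modest, but it runs towards a weaker inhibitor, so in this one pair adding methoxy at this aromatic carbon costs some inhibition rather than gaining any. No available evidence explains the change.

A single pair cannot show whether the loss belongs to methoxy itself or would follow any group on this carbon, and a hydroxyl group or a fluorine atom in the same place would help separate those two readings. It also leaves open whether methoxy would act the same way on the other carbons of that ring, or alongside the (1-bromoethenyl)carbonyl group of compound 1.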